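The compounds below may be only part of what the source reports. "The series", "measured", "known", "first", "only" and "open" are said of these compounds alone.

Measured so far in a functional assay on IMR-32 cells (Homo sapiens) for inhibition, with a stated time of 48 h, tested at 50 uM; a lower number here means less inhibition of growth, a higher number more inhibition of growth at the concentration tested:
compound 1 `C=C[C@@](C)(/C=C/c1ccc(OC(=O)CCCCC)cc1)CCC=C(C)C` gives 19%
compound 2 `COc1ccccc1/C=C/[C@@](C)(/C=C/c1ccc(O)cc1)CCC=C(C)C` gives 68%

Compound 2 stands highest of the two numbers, and its gap to compound 1 lies beyond the scatter. Compound 3 `CC(C)=CCC[C@](C)(/C=C/c1ccc(O)cc1)/C=C/c1ccc(F)cc1` keeps the rest of compound 2 and makes one change, 4-fluorophenyl in place of 2-methoxyphenyl on a double-bonded chain carbon bound to a double-bonded chain carbon on a double-bonded chain carbon bound to a double-bonded chain carbon. Going by the values given here, no measured pair isolates this change, so the estimated step of a number 8 percentage points lower from compound 2 to compound 3 (within the scatter) in this assay is expected to be a slight fall, not beyond the scatter. Compound 3 is estimated at 60% with 38% to 80% as the expected range.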

Compound 3, percent growth inhibition at one concentration: 37%
The estimate for compound 3 lay 23 percentage points above the measured number, and the stated range ends above it.
By their numbers in this assay, from the lowest: compound 1; then compound 3; then compound 2.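

In this assay, going by these compounds alone, the group on a double-bonded chain carbon bound to a double-bonded chain carbon is not interchangeable: 4-fluorophenyl in place of 2-methoxyphenyl gives a number 31 percentage points lower from compound 2 to compound 3 (beyond the scatter) as the first single-place step. Growth inhibition at the concentration tested therefore responds to which substituted phenyl stands at this place. No available evidence accounts for the size of this step.

The change replaces both the substituent and its ring position, so the two contributions remain unseparated. Unsubstituted phenyl, 4-methoxyphenyl and 2-fluorophenyl at this place would divide them.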